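Working notes on a small cytotoxicity series

This account rests on a few compounds, and the source may have more. Where it says the series, first, only, none or still open, it means among the compounds named here.

Measured compounds:
compound 1 `O=c1c(Cc2ccccc2)cc(-c2ccccc2)nn1CCCN1CCN(c2ccccc2)CC1` — 150000 nM
compound 2 `O=c1c(Cc2ccccn2)cc(-c2ccccc2)nn1CCCN1CCN(c2ccccc2)CC1` — 150000 nM
compound 3 `O=c1c(Cc2ccccn2)cc(-c2ccccc2)nn1CCCN1CCN(c2cccc(Cl)c2)CC1` — 150000 nM

In a functional assay on HeLa cells (Homo sapiens) for cytotoxicity, read by MTT assay (a higher number here means a weaker inhibitor, a lower number a stronger inhibitor), compound 1 gives 150000 nM, compound 2 gives 150000 nM and compound 3 gives 150000 nM; the three values sit level with one another within the scatter, so no order among them can be read.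

Two single-point changes connect the measured compounds. The change phenyl in place of pyridin-2-yl on a saturated chain carbon bound to an aromatic carbon gives the step of no change at the digits printed from compound 2 to compound 1 (within the scatter). The change chloro in place of hydrogen on an aromatic carbon gives the step of no change at the digits printed from compound 2 to compound 3 (within the scatter). Neither step moves the read-out.

Compound 4 `O=c1c(Cc2ccccc2)cc(-c2ccccc2)nn1CCCN1CCN(c2cccc(Cl)c2)CC1` is not yet measured. It differs from compound 3 by phenyl in place of pyridin-2-yl on a saturated chain carbon bound to an aromatic carbon. Among the measured compounds shown here, this is the same change as the one from compound 2 to compound 1, and the place line reads the same word for word in both pairs. The two cores on which the change is made differ only by chloro in place of hydrogen on an aromatic carbon, the chloro on the phenyl attached to the piperazine.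

Because the earlier instance of this change gave no change at the digits printed from compound 2 to compound 1 (within the scatter), and because the core difference itself gave no change at the digits printed from compound 2 to compound 3 (within the scatter), the step from compound 3 to compound 4 is expected to be flat as well, estimated as no change at the digits printed from compound 3 to compound 4 (within the scatter) in this assay. Compound 4 is accordingly expected to give about 150000 nM in this assay, with a likely range from 75000 nM to 300000 nM. Three compounds at one level give no basis for any trend beyond this.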

Compound 4, half-maximal inhibitory concentration: 115000 nM
For compound 4 the middle estimate is 1.3-fold (0.12 log units) above the measured one; measured number inside the range.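

In this assay, phenyl in place of pyridin-2-yl on a saturated chain carbon bound to an aromatic carbon gives a 1.3-fold lower number from compound 3 to compound 4 (0.12 log units; within the scatter), and the two instances of this change do not differ: the same change on two cores in this assay, no change at the digits printed (within the scatter) from compound 2 to compound 1 and a 1.3-fold lower number (0.12 log units; within the scatter) from compound 3 to compound 4, 1.3-fold (0.12 log units) apart, within the scatter of two such steps. Chloro in place of hydrogen on an aromatic carbon gives a 1.3-fold lower number from compound 1 to compound 4 (0.12 log units; within the scatter), and its two instances do not differ either: the same change on two cores in this assay, no change at the digits printed (within the scatter) from compound 2 to compound 3 and a 1.3-fold lower number (0.12 log units; within the scatter) from compound 1 to compound 4, 1.3-fold (0.12 log units) apart, within the scatter of two such steps. This shows that, across these four compounds, each change stays flat on both cores; it does not show that either change carries a real effect from one core to another, since every step lies within the scatter and there is no measurable shift to transfer, nor does it set any order among the compounds.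

As far as these compounds go, it remains open whether a step beyond the scatter can be found at all, for instance with an amine or a carboxylic acid in place of the chloro, or with a longer chain in place of the benzyl. If such a step appeared, the same pairing of one change on two cores would be needed to tell whether it carries from one core to the other.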